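The compounds below may be only part of what the source reports. "The series", "measured", "known", "first", "only" and "open" are said of these compounds alone.

Working notes on the series. Compound 1 `CCOc1cc(C(C)(C)C)ccc1C1=NC(c2ccc(Cl)cc2)C(c2ccc(Cl)cc2)N1C(=O)N1CCN(Cc2ccc(C(=O)NO)cc2)CC1` in an assay on isolated protein for inhibition of E3 ubiquitin-protein ligase Mdm2 (Homo sapiens), read by fluorescence polarization, with a stated time of 30 min (a higher number here means a weaker inhibitor, a lower number a stronger inhibitor), gives 260 nM; compound 2 `CCOc1cc(C(C)(C)C)ccc1C1=NC(c2ccc(Cl)cc2)C(c2ccc(Cl)cc2)N1C(=O)N1CCN(CCCCC(=O)NO)CC1` gives 170 nM; compound 3 `CCOc1cc(C(C)(C)C)ccc1C1=NC(c2ccc(Cl)cc2)C(c2ccc(Cl)cc2)N1C(=O)N1CCN(c2ncc(C(=O)NO)cn2)CC1` gives 1050 nM, the highest number of the three, standing apart from both others beyond the scatter.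

The next compound, compound 4 `CCOc1cc(C(C)(C)C)ccc1C1=NC(c2ccc(Cl)cc2)C(c2ccc(Cl)cc2)N1C(=O)N1CCN(CCCCCCCC(=O)NO)CC1`, differs from compound 3 in one place: 7-(hydroxycarbamoyl)heptyl in place of 5-(hydroxycarbamoyl)pyrimidin-2-yl on an amine nitrogen in a ring. The measured steps that bear on this are a 6.2-fold higher number from compound 2 to compound 3 (0.79 log units; beyond the scatter) and a 4.0-fold higher number from compound 1 to compound 3 (0.61 log units; beyond the scatter), both moving against the pyrimidinyl group; the comparison of the two open chains with a ring, a 1.5-fold lower number from compound 1 to compound 2 (0.18 log units; within the scatter), stayed within the scatter. Replacing the pyrimidinyl group by a longer open chain is therefore expected to lower the number in this assay by roughly the size seen on leaving compound 2, giving a step of about a 6.6-fold lower number from compound 3 to compound 4 (0.82 log units; beyond the scatter). Compound 4 is expected to give 160 nM, with a range of 60 nM to 450 nM.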

Compound 4, inhibition constant: 290 nM
Compound 4: middle estimate off by 1.8-fold (0.26 log units), on the low side, within the range that was stated.
By their numbers in this assay, from the lowest: compounds 2, 1 and 4 (each within the scatter of the next); then compound 3.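

In this assay the pyrimidinyl group is the outlier at this position: 7-(hydroxycarbamoyl)heptyl on the amine nitrogen in the ring gives (a 3.6-fold lower number from compound 3 to compound 4 (0.56 log units; beyond the scatter)), beyond the scatter. The long open chain cannot be told apart from the shorter chain (a 1.7-fold higher number from compound 2 to compound 4 (0.23 log units; within the scatter)) or from the benzyl group (a 1.1-fold higher number from compound 1 to compound 4 (0.05 log units; within the scatter)), both within the scatter, so this position tolerates a wide change in linker without a resolved effect on the number. No measurement at hand explains the separate standing of compound 3.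

As far as these compounds go, whether a longer chain holds this level remains open. So does whether a carboxylic acid in place of the hydroxycarbamoyl end would.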